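Two Triazole Analogues and an Ethoxy Replacement

The compounds below may be only part of what the source reports. "The series", "measured", "known", "first", "only" and "open" are said of these compounds alone.

Compound 1 `N#CC1=C(N)Oc2c(N)cc3nc4ccccc4nc3c2C12C(=O)N(Cc1cnnn1-c1ccc(F)cc1)c1ccccc12` and compound 2 `N#CC1=C(N)Oc2c(N)cc3nc4ccccc4nc3c2C12C(=O)N(Cc1cnnn1-c1ccccc1Br)c1ccccc12` share one core and differ only in the group carried on an aromatic nitrogen. In a functional assay on HepG2 cells (Homo sapiens) for antiproliferative activity, read by MTT assay, with a stated time of 48 h (a lower number here means a stronger inhibitor, a higher number a weaker inhibitor), compound 1 gives > 50000 nM, which is a limit of the measurement rather than a number. In this assay compound 2 gives 38000 nM. Putting 2-bromophenyl in place of 4-fluorophenyl on an aromatic nitrogen gives an at least 1.3-fold lower number from compound 1 to compound 2 (0.11 log units; that floor lies within the scatter). Compound 2 therefore holds the only number shown. The value of compound 1 is a limit (the limit of > 50000 nM in this assay, at which 1 of the 2 values shown sits). Compound 3 `CCOc1ccccc1-n1nncc1CN1C(=O)C2(C(C#N)=C(N)Oc3c(N)cc4nc5ccccc5nc4c32)c2ccccc21` is the next step: ethoxy in place of bromo on an aromatic carbon. For the measured compounds named here, no measured step replaces a bromo by an ethoxy; the only step seen, from compound 1 to compound 2, touches a different group and stays near the scatter, so it offers little guidance. For compound 3 the expected step is therefore a 1.1-fold lower number from compound 2 to compound 3 (0.04 log units; within the scatter), nothing beyond the scatter. Compound 3 is estimated at 35000 nM, with a range from 12000 nM to 100000 nM, and with a fair chance that this assay again reports only a limit.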

Compound 3, half-maximal inhibitory concentration: 30500 nM
Estimate against measurement, compound 3: 1.1-fold (0.06 log units) above; low and high end bracket the measured number.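

Ethoxy in place of bromo on this aromatic carbon, ortho to a large group, gives a 1.2-fold lower number from compound 2 to compound 3 (0.10 log units; within the scatter), the first step here read between two actual numbers, so in this assay the two groups cannot be told apart at this position, even though ethoxy brings an oxygen and a short chain where bromo is a single atom. Changing the whole aryl group, 2-ethoxyphenyl in place of 4-fluorophenyl, gives an at least 1.6-fold lower number from compound 1 to compound 3 (0.21 log units; that floor lies within the scatter), so the floor on this step also stays within the scatter. That step cannot be sized any further, since the value of compound 1 is a limit and not a number: the limit of > 50000 nM in this assay, at which 1 of the 3 values shown sits.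

Going by these compounds, whether any group on this carbon can move the number beyond the scatter remains open, and an amine, a carboxylic acid or a longer chain such as butoxy in place of ethoxy would put that to the test. Also open, on these data alone, is whether ethoxy would read the same on another carbon of this ring, which compound 2 and compound 3 cannot tell.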